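A few compounds are considered here, and "the series" means these few. Any claim that something is new, unique, unknown or untested is made for them only; others in the source may bear on it.

Measured compounds:
compound 1 `CS(=O)(=O)c1ccc(S(=O)(=O)c2ccc(CN)s2)cc1` — 67%
compound 2 `NCc1ccc(S(=O)(=O)c2cccc(S(=O)(=O)N3CCC[C@H]3CO)c2)s1` — 63%
compound 3 `CC(=O)NCCS(=O)(=O)c1ccc(S(=O)(=O)c2ccc(CN)s2)cc1` — 91%

In an ADME assay on microsomes from liver (Mus musculus, strain Balb/c) for metabolic stability, read by LC-MS, with a stated time of 30 min, tested at 10 uM (on this read-out higher numbers stand for a more stable compound and lower numbers for a less stable compound), compound 1 sits within the scatter of compound 2, so the two are not told apart, while compound 3 lies beyond the scatter above both. Among the compounds with values here, the one step that starts from compound 1 is a number 24 percentage points higher from compound 1 to compound 3 (beyond the scatter), brought about by acetamidomethyl in place of hydrogen on a saturated chain carbon bound to a sulfonyl sulfur.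

Compound 4 `CS(=O)(=O)c1ccc(S(=O)(=O)c2ccc(CN)s2)cc1-c1ccccc1` differs from compound 1 by phenyl in place of hydrogen on an aromatic carbon. Within the data shown here, no measured step covers a phenyl entering on an aromatic carbon, ortho to a methylsulfonyl group and meta to a large group; the step from compound 1 to compound 3 concerns a saturated chain carbon and a different group, so it gives no direct guide. With nothing to point either way, no step beyond the scatter is expected in this assay, and compound 4 is estimated at 65%, between 45% and 85%, which is expected to mean a number 2 percentage points lower from compound 1 to compound 4 (within the scatter).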

Compound 4, percent of the compound remaining: 41%
Estimate against measurement, compound 4: 24 percentage points above; the measured number lies below the stated range.
By their numbers in this assay, from the lowest: compound 4; then compounds 2 and 1 (each within the scatter of the next); then compound 3.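

In this assay, the aromatic carbon ortho to a methylsulfonyl group and meta to a large group proves sensitive to substitution: phenyl in place of hydrogen gives a number 26 percentage points lower from compound 1 to compound 4 (beyond the scatter). Set against a number 24 percentage points higher from compound 1 to compound 3 (beyond the scatter), this shows that changes to the core of compound 1 can move the number beyond the scatter in either direction, although the two steps differ in both the place and the entering group, so they do not separate the two. No measurement available here accounts for the drop with phenyl.

From the compounds shown here alone, it remains open whether the drop belongs to phenyl itself or would also follow a smaller group, such as methyl or a single fluorine atom, at this carbon. Going by these compounds, it is equally open whether an amine or a carboxylic acid on the entering phenyl would change the number.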